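Neopentyl series: methyl to fluoro on the benzamide ring

This account rests on a few compounds, and the source may have more. Where it says the series, first, only, none or still open, it means among the compounds named here.

Measured so far:
compound 1 `Cc1ccc(C(=O)Nc2nc(Cl)c3cn(CC(C)(C)C)nc3n2)cc1`: 11100 nM
compound 2 `Cc1ccc(C(=O)Nc2nc(Cl)c3cn(C(C)C)nc3n2)cc1`: 4100 nM

Compound 1 gives the highest of the two numbers in an assay on CHO cells for displacement of a labelled ligand from adenosine receptor A1 (Homo sapiens), read by scintillation counting, with a stated time of 3 h; on this read-out higher numbers stand for weaker inhibition and lower numbers for stronger inhibition; its nearest neighbour is compound 2, reached by a 2.7-fold lower number from compound 1 to compound 2 (0.43 log units; beyond the scatter), a modest step beyond the scatter that comes from swapping the group on the aromatic nitrogen.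

Compound 3 `CC(C)(C)Cn1cc2c(Cl)nc(NC(=O)c3ccc(F)cc3)nc2n1` keeps the neopentyl group of compound 1 and changes only the benzamide ring: fluoro in place of methyl on an aromatic carbon. Among the compounds with values here, no measured step touches this position; the only step in hand, from compound 1 to compound 2, concerns the aromatic nitrogen and so says nothing about the benzamide ring. With no bearing data, the expectation for compound 3 in this assay is a number not far from compound 1, with no step beyond the scatter asserted in either direction. The estimated step from compound 1 to compound 3 is a 1.2-fold lower number from compound 1 to compound 3 (0.07 log units; within the scatter), and compound 3 is expected at about 9500 nM, within a range from 3000 nM to 30000 nM.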

Compound 3, inhibition constant: 16500 nM
The estimate for compound 3 lay 1.7-fold (0.24 log units) below the measured number; the range from low to high includes it.
By their numbers in this assay, from the lowest: compound 2; then compounds 1 and 3 (each within the scatter of the next).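

In this assay, within the data shown here, the change from 4-methylphenyl to 4-fluorophenyl gives the first reading at this position (a 1.5-fold higher number from compound 1 to compound 3 (0.17 log units; within the scatter)), and the step stays within the scatter. The swap of methyl for fluoro on this aromatic carbon therefore does not separate compound 3 from compound 1, whereas the change on the aromatic nitrogen (a 2.7-fold lower number from compound 1 to compound 2 (0.43 log units; beyond the scatter)) lies beyond the scatter. No supporting data bear on this result, so it stands as an observation only (see).

As far as these compounds go, whether an amine, a carboxylic acid or a longer chain at this position would move the number beyond the scatter remains open. Also open, from the compounds shown here alone, is whether methyl and fluoro would stay within the scatter of each other with isopropyl in place of neopentyl on the aromatic nitrogen.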